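The compounds below may be only part of what the source reports. "The series", "measured", "known", "first", "only" and "open" are said of these compounds alone.

Compound 1 `CC1(C)Oc2cc(NS(=O)(=O)C3CCCCC3)ccc2NC1=O`: 8400 nM
Compound 2 `CC1(C)Oc2cc(NS(=O)(=O)c3ccc(F)cc3Cl)ccc2NC1=O`: 7800 nM

In a functional assay on LNCaP cells (Homo sapiens) for antiproliferative activity, read by luminescence, with a stated time of 96 h (a lower number here means a stronger inhibitor, a higher number a weaker inhibitor), compound 2 gives 7800 nM, the lowest of the two numbers shown, while compound 1 gives 8400 nM; the gap between the two lies within the usual scatter, so the two compounds cannot be told apart on these numbers.

Compound 3 `CC1(C)Oc2cc(NS(=O)(=O)c3ccccc3)ccc2NC1=O` has not yet been measured. It differs from compound 2 in one place: phenyl in place of 2-chloro-4-fluorophenyl on a sulfonyl sulfur. Going by the values given here, the only measured step that bears on this change is the one from compound 1 to compound 2, a 1.1-fold lower number from compound 1 to compound 2 (0.03 log units; within the scatter), in which a cyclohexyl group was exchanged for the 2-chloro-4-fluorophenyl group without any shift beyond the scatter. That step suggests the group on the sulfonyl sulfur has so far made little difference to the number. Replacing the 2-chloro-4-fluorophenyl group by a plain phenyl group is therefore expected to give only a small step, a 1.1-fold higher number from compound 2 to compound 3 (0.04 log units; within the scatter), with no clear direction beyond the scatter. Compound 3 is estimated at 8500 nM in this assay, with a likely range from 3000 nM to 25000 nM.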

Compound 3, half-maximal inhibitory concentration: 7520 nM
Compound 3: the middle estimate sits 1.1-fold (0.05 log units) above what was measured, within the range that was stated.
By their numbers in this assay, from the lowest: compounds 3, 2 and 1 (each within the scatter of the next).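

In this assay, taking the chlorine and the fluorine off the ring on the sulfonyl sulfur gives a 1.0-fold lower number from compound 2 to compound 3 (0.02 log units; within the scatter) and stays within the scatter, so phenyl and 2-chloro-4-fluorophenyl cannot be told apart at this position. Phenyl and cyclohexyl cannot be told apart here either, with a 1.1-fold lower number from compound 1 to compound 3 (0.05 log units; within the scatter) also within the scatter, so all three groups now give matching results, whether the ring is aromatic or not and whether it carries halogens or not. Nothing measured here explains why these numbers stay together.

Still open, as far as these compounds go, is whether any group on the sulfonyl sulfur can move the number beyond the scatter, since all three compounds carry a six-membered carbon ring there and a group holding an amine or a carboxylic acid, or a longer alkyl chain, would probe something different. The compounds shown also share one core, so they leave open how much a change elsewhere on that core would matter.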